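This account rests on a few compounds, and the source may have more. Where it says the series, first, only, none or still open, it means among the compounds named here.

Measured so far:
Compound 1, `CC(C(=O)NCc1ccc(C(F)(F)F)nc1NCc1ccc(Cl)cc1)c1ccc(NS(C)(=O)=O)c(F)c1` — in a functional assay on CHO-K1 cells for antagonist activity at transient receptor potential cation channel subfamily V member 1 (Homo sapiens), read by FLIPR (on this read-out lower numbers stand for stronger inhibition and higher numbers for weaker inhibition), compound 1 gives 414 nM.
Compound 2, `CC(C(=O)NCc1ccc(C(F)(F)F)nc1N1CCC(O)CC1)c1ccc(NS(C)(=O)=O)c(F)c1` — in this assay compound 2 gives "not active" (no number reported), a report without a number.

Among the measured compounds shown here, compound 1 is the only compound of the set with a numerical value in this assay; compound 2 was reported without a number, so no step between the two measured compounds can be given, and nothing is said here of how compound 2 differs from compound 1.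

The next compound, compound 3, `CC(=O)OC1CCN(c2nc(C(F)(F)F)ccc2CNC(=O)C(C)c2ccc(NS(C)(=O)=O)c(F)c2)CC1`, carries the same core as compound 1 with one change: 4-acetoxypiperidin-1-yl in place of (4-chlorobenzyl)amino on an aromatic carbon. The outcome of this change in this assay cannot be read from a step between measured compounds. What is known is that compound 1 gives 414 nM in this assay and that compound 2 gives "not active" (no number reported) there. On that footing the step of a 12-fold higher number from compound 1 to compound 3 (1.08 log units; beyond the scatter) is expected to be a loss beyond the usual scatter. For compound 3 the estimate in this assay is 5000 nM, with a range from 1200 nM to 25000 nM.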

Compound 3, half-maximal inhibitory concentration: 139 nM
The estimate for compound 3 lay 36-fold (1.56 log units) above the measured number; measured number below the stated range.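

The change shows that, at this position next to the ring nitrogen, (4-chlorobenzyl)amino is not required for activity in this assay: replacing it with 4-acetoxypiperidin-1-yl gives a 3.0-fold lower number from compound 1 to compound 3 (0.47 log units; beyond the scatter), a modest change that lies beyond the scatter. The new group has a six-membered non-aromatic ring in place of the all-carbon aromatic ring and has no hydrogen-bond donors, so neither the aromatic ring nor the donor of (4-chlorobenzyl)amino is needed for a measurable number at this position. No measured information available here explains why the number falls.

Among the compounds shown here, compound 2 has no number, so no step to it can be read, and this single step cannot separate the contribution of the piperidine ring from that of its acetoxy group. On these data alone, it remains open how a plain piperidin-1-yl, a 4-methoxypiperidin-1-yl or a morpholin-4-yl group would stand at this position in this assay, and whether a benzylamino group without the chlorine would differ from the (4-chlorobenzyl)amino group of compound 1.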